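Two methoxyphenyl isomers on a shared core, one assay

The source may report more compounds than this note shows. Statements on the series, on what has been measured and on what is new or still open speak of the compounds shown alone.

Compound 1 `COc1ccc(NC(=O)Cn2cc(COc3ccc4c(c3)CCC4)nn2)cc1` gives "not determined" (no result reported) in an ADME assay on HEK293 cells (Homo sapiens) for inhibition, read by MTT assay, with a stated time of 48 h, tested at 25 uM (a higher number here means more inhibition at the concentration tested (going by the name of the read-out), a lower number less inhibition), that is, no result. Among the compounds with values here, compound 2 `COc1ccccc1-n1cc(COc2ccc3c(c2)CCC3)nn1`, on the shared core, gives 19.8% in this assay; this is the only number so far, so compound 2 stands alone with nothing to rank against. Compound 3 `COc1ccc(-n2cc(COc3ccc4c(c3)CCC4)nn2)cc1` is not yet measured. It differs from compound 2 by 4-methoxyphenyl in place of 2-methoxyphenyl on an aromatic nitrogen, the same atoms joined differently. Within the data shown here, no measured pair shows how such a change moves the read-out; the expectation is a step of a number 0.2 percentage points higher from compound 2 to compound 3 (within the scatter) of no more than the usual scatter, in either direction. Compound 3 is therefore estimated at 20%, with a range from 5% to 38%.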

Compound 3, a percentage reported as inhibition, at one concentration (the size of the read-out at that concentration, not a potency): 21.1%
Estimate against measurement, compound 3: 1.1 percentage points below; low and high end bracket the measured number.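

Within the data shown here, with 4-methoxyphenyl in place of 2-methoxyphenyl on an aromatic nitrogen, this assay gives a number 1.3 percentage points higher from compound 2 to compound 3 (within the scatter) and so provides the first measured pair at this position. Within this pair, the two methoxyphenyl isomers are not told apart by this assay at this position. No accompanying data bear on this result.

Still open, from the compounds shown here alone, is how 3-methoxyphenyl would read at this position. Also open, going by these compounds, is whether an amine or a carboxylic acid in place of the methoxy group on the phenyl ring would leave the read-out within the same narrow span.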